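The source may hold more compounds than are shown below. What is called first, only, known or untested is meant among the compounds shown, and "the series" means these compounds.

Values in a functional assay on A549 cells (Homo sapiens) for antiproliferative activity, read by MTT assay, with a stated time of 72 h; on this read-out higher numbers stand for weaker inhibition and lower numbers for stronger inhibition:
Compound 1 `COc1ccccc1-c1ccc2ncn(-c3cc(OC)c(OC)c(OC)c3)c2c1`: 4320 nM.
Compound 2 `COc1cc(-n2cnc3ccc(-c4ccccc4Cl)cc32)cc(OC)c1OC`: > 10000 nM, a limit of the assay and not a number.
Compound 3 `COc1ccc(-c2ccc3ncn(-c4cc(OC)c(OC)c(OC)c4)c3c2)cc1F`: 1430 nM.

Compound 3 has the lower of the two true numbers in this assay, and compound 1 is its nearest neighbour: a 3.0-fold lower number from compound 1 to compound 3 (0.48 log units; beyond the scatter). The next analogue, compound 4 `COc1cc(-n2cnc3ccc(-c4ccc(C(F)(F)F)cc4)cc32)cc(OC)c1OC`, has 4-(trifluoromethyl)phenyl in place of 3-fluoro-4-methoxyphenyl on an aromatic carbon.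

All three measured steps change the aryl group at this same place: a 3.0-fold lower number from compound 1 to compound 3 (0.48 log units; beyond the scatter), an at least 2.3-fold higher number from compound 1 to compound 2 (0.36 log units; beyond the scatter) and an at least 6.9-fold lower number from compound 2 to compound 3 (0.84 log units; beyond the scatter). Compound 2 is the closest guide, as its 2-chlorophenyl group also carries no methoxy, and the step to it from compound 1 is an at least 2.3-fold higher number from compound 1 to compound 2 (0.36 log units; beyond the scatter). However, with only three compounds, this is a weak guide. A modest rise in the number is therefore expected, and the estimated step is a 3.1-fold higher number from compound 3 to compound 4 (0.50 log units; beyond the scatter). For compound 4 the expected value is 4500 nM, with an estimated range of 1500 nM to 10000 nM.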

Compound 4, half-maximal inhibitory concentration: 3390 nM
The estimate for compound 4 lay 1.3-fold (0.12 log units) above the measured number, and the stated range covers the measured number.
By their numbers in this assay, from the lowest: compound 3; then compounds 4 and 1 (each within the scatter of the next). At a limit, above all of these: compound 2.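

Compound 4 shows that an aryl group with no methoxy and no hydrogen-bond acceptor can still give a true number in this assay, although compound 3 keeps the lower number (a 2.4-fold higher number from compound 3 to compound 4 (0.37 log units; beyond the scatter)). Replacing the 2-methoxyphenyl group of compound 1 with 4-(trifluoromethyl)phenyl leaves the value within the scatter (a 1.3-fold lower number from compound 1 to compound 4 (0.11 log units; within the scatter)), while the two aryl groups without methoxy are clearly separated (an at least 2.9-fold lower number from compound 2 to compound 4 (0.46 log units; beyond the scatter)), so losing the methoxy does not by itself place a compound at the limit. Compound 2 remains a limit of the assay and not a number: the limit of > 10000 nM in this assay, at which 1 of the 4 values shown sits.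

Whether the fluorine or the methoxy of compound 3 accounts for its lower number remains open. So does how an amine or a carboxylic acid on this aryl ring would read.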